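Methoxyphenyl in Place of Trifluoromethylphenyl on the Acid

The compounds below may be only part of what the source reports. "The series", "measured", "known", "first", "only" and "open" are said of these compounds alone.

Compound 1 `CCOC(=O)C1=Cc2ccccc2OC1(OCc1cc(-c2ccc(OC)cc2)no1)C(F)(F)F`: in a functional assay on A549 cells (Homo sapiens) for inhibition, read by MTT assay, with a stated time of 24 h (a higher number here means a weaker inhibitor, a lower number a stronger inhibitor), compound 1 gives > 150000 nM, a limit of the assay rather than a number.
Compound 2 `CCOC(=O)C1=Cc2ccccc2OC1(OCc1cc(-c2cccc(C(F)(F)F)c2)no1)C(F)(F)F`: compound 2 gives 48600 nM.
Compound 3 `O=C(O)C1=Cc2ccccc2OC1(OCc1cc(-c2cccc(C(F)(F)F)c2)no1)C(F)(F)F`: compound 3 gives > 150000 nM, again a limit rather than a number.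

Compound 1 differs from compound 2 by 4-methoxyphenyl in place of 3-(trifluoromethyl)phenyl on an aromatic carbon, and that change made an at least 3.0-fold higher number from compound 2 to compound 1 (0.48 log units; beyond the scatter). The two cores differ by hydrogen in place of ethyl on an oxygen next to a carbonyl group, which gave an at least 3.0-fold higher number from compound 2 to compound 3 (0.48 log units; beyond the scatter). Compound 4 `COc1ccc(-c2cc(COC3(C(F)(F)F)Oc4ccccc4C=C3C(=O)O)on2)cc1` has not been measured; it differs from compound 3 by 4-methoxyphenyl in place of 3-(trifluoromethyl)phenyl on an aromatic carbon, the same change as from compound 2 to compound 1. The two place descriptions agree word for word. Two of the three values already sit at the limit of > 150000 nM in this assay, at which 2 of the 3 values shown sit. Because compound 3 stands at > 150000 nM, a limit, the step in this assay cannot be measured as a number. The expected step is a step that the limit leaves unreadable from compound 3 to compound 4. Compound 4 is expected to give about 400000 nM, between 150000 nM and 1500000 nM.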

Compound 4, half-maximal inhibitory concentration: 36200 nM
Compound 4: the middle estimate sits 11-fold (1.04 log units) above what was measured; measured number below the stated range.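

In this assay, 4-methoxyphenyl in place of 3-(trifluoromethyl)phenyl gave an at least 4.1-fold lower number from compound 3 to compound 4 (0.61 log units; beyond the scatter), so this change does not carry over unchanged from one core to the other: the same change on two cores in this assay, an at least 3.0-fold higher number (0.48 log units; beyond the scatter) from compound 2 to compound 1 and an at least 4.1-fold lower number (0.61 log units; beyond the scatter) from compound 3 to compound 4, at least 12-fold (1.10 log units) apart, beyond the scatter of two such steps

Hydrogen in place of ethyl gave an at least 4.1-fold lower number from compound 1 to compound 4 (0.61 log units; beyond the scatter), and this change too depends on the core: the same change on two cores in this assay, an at least 3.0-fold higher number (0.48 log units; beyond the scatter) from compound 2 to compound 3 and an at least 4.1-fold lower number (0.61 log units; beyond the scatter) from compound 1 to compound 4, at least 12-fold (1.10 log units) apart, beyond the scatter of two such steps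

Compound 1 and compound 3 each stand at a limit of the assay; the sizes of these steps are therefore only bounds, and no reason for the reversal is shown.

Still open, from the compounds shown here alone, is whether the reversal holds for other groups on the same ring carbon, such as 4-chlorophenyl or plain phenyl. Also open, going by these compounds, is what an amide in place of the ester or acid would do.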